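Working notes: cyano to aminomethyl on the shared core

The source may report more compounds than this note shows. Statements on the series, on what has been measured and on what is new or still open speak of the compounds shown alone.

Measured in an ADME assay on HEp-2 cells (Homo sapiens) for cytotoxicity; on this read-out lower numbers stand for higher toxicity in this test and higher numbers for lower toxicity in this test:
- compound 1 `C=C(C)n1c(=O)n(Cc2nc3ccccc3n2CCC(C)C)c2ccccc21` gives 24600 nM
- compound 2 `CC(C)CCn1c(Cn2c(=O)n(C(C)C)c3ccccc32)nc2cc(CNS(C)(=O)=O)ccc21` gives 30800 nM
- compound 3 `CC(C)CCn1c(Cn2c(=O)n(C(C)C)c3ccccc32)nc2ccc(C#N)cc21` gives 10000 nM

Compound 3 (10000 nM) has the lowest number of the three and so the highest toxicity in this test. Compound 1 and compound 2 both lie above it, each by a gap beyond the usual scatter. The next compound to be tested is compound 4 `CC(C)CCn1c(Cn2c(=O)n(C(C)C)c3ccccc32)nc2ccc(CN)cc21`, which differs from compound 3 in one place (aminomethyl in place of cyano on an aromatic carbon). Aminomethyl stands in place of cyano on an aromatic carbon.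

Going by the values given here, no two measured compounds differ in one place only, so the series offers no direct precedent for this change. Among the compounds with values here, the only guide is the spread of the three values, which runs from compound 3 (10000 nM) to compound 2 (30800 nM). That spread is narrow, so a large move is not expected, though the range has to stay wide. The expected step of a 1.4-fold higher number from compound 3 to compound 4 (0.15 log units; within the scatter) is small and upward, within the scatter. In this assay the estimate for compound 4 is 14000 nM (expected range from 5000 nM to 38000 nM).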

Compound 4, half-maximal cytotoxic concentration: 28100 nM
Compound 4: middle estimate off by 2.0-fold (0.30 log units), on the low side; the measured number falls inside the stated range.
By their numbers in this assay, from the lowest: compound 3; then compounds 1, 4 and 2 (each within the scatter of the next).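

In this assay, going by these compounds alone, this position gives the first single-change comparison: aminomethyl in place of cyano on an aromatic carbon yields a 2.8-fold higher number from compound 3 to compound 4 (0.45 log units; beyond the scatter) and counts as a modest step. The position therefore responds to substitution even though the group entering has the same number of heavy atoms as the group leaving, with one hydrogen-bond donor added and no net charge on either group. The higher toxicity in this test seen with the cyano group on this carbon does not persist with aminomethyl, but nothing available explains the step.

On these data alone, it remains open whether the step depends on the amine nitrogen or on the carbon that carries it, a question that a hydroxymethyl group or a dimethylaminomethyl group on the same aromatic carbon would help to settle. As far as these compounds go, it also remains open whether a longer chain ending in an amine, such as aminoethyl, would stay close to compound 4 at 28100 nM in this assay or move away from it.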